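Aryl group changes at the chain end of a shared core

A few compounds are considered here, and "the series" means these few. Any claim that something is new, unique, unknown or untested is made for them only; others in the source may bear on it.

Measured compounds in a functional assay on B16-F10 cells (Mus musculus) for inhibition, read by MTT assay, with a stated time of 48 h; on this read-out higher numbers stand for weaker inhibition and lower numbers for stronger inhibition:
- compound 1 `O=C(/C=C/c1ccccc1Br)Nc1ccc2ncnc(Nc3cccc(Cl)c3)c2c1`: 1.65 ug/mL
- compound 2 `Cc1ccc(/C=C/C(=O)Nc2ccc3ncnc(Nc4cccc(Cl)c4)c3c2)cc1`: 2.02 ug/mL
- compound 3 `O=C(/C=C/c1cccc2ccccc12)Nc1ccc2ncnc(Nc3cccc(Cl)c3)c2c1`: 0.671 ug/mL

Compound 3 gives the lowest number of the three. Compounds 1 and 2 sit together: a 1.2-fold higher number from compound 1 to compound 2 (0.09 log units; within the scatter). Putting naphthalen-1-yl at the chain end gave a 2.5-fold lower number from compound 1 to compound 3 (0.39 log units; beyond the scatter) and a 3.0-fold lower number from compound 2 to compound 3 (0.48 log units; beyond the scatter), both modest and beyond the scatter.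

Compound 4 `O=C(/C=C/c1ccc([N+](=O)[O-])cc1)Nc1ccc2ncnc(Nc3cccc(Cl)c3)c2c1` differs from compound 3 as follows: 4-nitrophenyl in place of naphthalen-1-yl on a double-bonded chain carbon bound to a double-bonded chain carbon. Among the measured compounds shown here, this step undoes the two-ring group of compound 3 and returns to a single six-membered ring, as in compound 1 and compound 2; the substituent on that ring, a nitro group, has no measured counterpart here. The two steps into compound 3, read in the opposite sense, are the ones that bear on it, and they suggest a modest rise in this assay. Compound 4 is therefore expected to give 1.6 ug/mL, with a range of 0.7 ug/mL to 3.6 ug/mL, meaning an estimated 2.4-fold higher number from compound 3 to compound 4 (0.38 log units; beyond the scatter).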

Compound 4, half-maximal inhibitory concentration: 2.05 ug/mL
Estimate against measurement, compound 4: 1.3-fold (0.11 log units) below; the range from low to high includes it.
By their numbers in this assay, from the lowest: compound 3; then compounds 1, 2 and 4 (each within the scatter of the next).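

In this assay, replacing the two-ring naphthalen-1-yl with a single ring at the chain end gives a 3.1-fold higher number from compound 3 to compound 4 (0.49 log units; beyond the scatter). Nitro in place of methyl on an aromatic carbon gives a 1.0-fold higher number from compound 2 to compound 4 (0.01 log units; within the scatter), and 4-nitrophenyl in place of 2-bromophenyl gives a 1.2-fold higher number from compound 1 to compound 4 (0.09 log units; within the scatter), so the three single-ring groups sit together despite their different substituents, and only the naphthalen-1-yl of compound 3 stands apart among these four compounds. Nothing available explains this separation.

Going by these compounds, whether the separation belongs to two-ring groups generally or to naphthalen-1-yl alone remains open, since naphthalen-2-yl or quinolin-4-yl at this place would be needed to tell. On these data alone, the effect of an amine or a carboxylic acid on the single ring also remains open.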